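A few compounds are considered here, and "the series" means these few. Any claim that something is new, unique, unknown or untested is made for them only; others in the source may bear on it.

Compound 1 `Nn1c(SCc2ccc([N+](=O)[O-])cc2)nnc1-c1c[nH]c2ccccc12`: 6900 nM
Compound 2 `COc1cccc(CSc2nnc(-c3c[nH]c4ccccc34)n2N)c1`: 12900 nM

Both compounds were tested for cytotoxicity in a functional assay on KG-1a cells (Homo sapiens) for cytotoxicity, with a stated time of 24 h; a higher number here means a weaker inhibitor, a lower number a stronger inhibitor. Repeated measurements of this kind naturally vary, so two close numbers need not reflect a real difference. Compound 2, at 12900 nM, stands within the usual scatter of compound 1, at 6900 nM, and these two results cannot be separated.

The next compound to be tested is compound 3 `Cc1ccc(CSc2nnc(-c3c[nH]c4ccccc34)n2N)cc1`. The change from compound 2 is 4-methylphenyl in place of 3-methoxyphenyl on a saturated chain carbon bound to a sulfur. Put simply, 4-methylphenyl sits in place of 3-methoxyphenyl on a saturated chain carbon bound to a sulfur.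

For the measured compounds named here, no measured pair here shows the effect of a single structural change, so the data offer no direct precedent for this step. Going by the values given here, the only guide is that compound 1 and compound 2 give values within the scatter of each other. On that limited evidence, no change beyond the scatter is expected in this assay, and no direction can be favoured with confidence. The estimated change is a 1.3-fold lower number from compound 2 to compound 3 (0.11 log units; within the scatter), and it is expected to remain within the scatter. For compound 3, the estimated value is 10000 nM, with an expected range of 4500 nM to 22000 nM.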

Compound 3, half-maximal inhibitory concentration: > 100000 nM
Compound 3: only a limit was reported; the forecaster's own chance of this, stated with the estimate: 5%; middle value at least 10-fold (1.00 log units) away from the limit.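

The reading for compound 3 in this assay is a limit and not a number: the limit of > 100000 nM in this assay, at which 1 of the 3 values shown sits. Even so, the aromatic group on a saturated chain carbon bound to a sulfur clearly matters: 4-methylphenyl in place of 3-methoxyphenyl gives an at least 7.7-fold higher number from compound 2 to compound 3 (0.88 log units; beyond the scatter), and methyl in place of nitro on an aromatic carbon gives an at least 14-fold higher number from compound 1 to compound 3 (1.16 log units; beyond the scatter). Compound 1 and compound 2 gave no sign of this, since their values lie within the scatter of each other, whereas compound 3 shows that a modest change in this group can take the cytotoxicity out of the measurable range.

From the compounds shown here alone, the step from compound 2 to compound 3 swaps the group on the ring and also its place on the ring, so it remains open which of the two matters, a question that 3-methylphenyl or 4-methoxyphenyl would help to settle. Going by these compounds, it is also open whether the loss is specific to methyl, or whether an amine or a carboxylic acid on the same ring would behave in the same way.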